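The source may report more compounds than this note shows. Statements on the series, on what has been measured and on what is new or still open speak of the compounds shown alone.

Compound 1 `Cc1cc2c(c(N)nn2C)c(N2CCCCC2)n1`: -152%
Compound 2 `COCCNc1nc(C)cc2c1c(N)nn2C`: -10%
Compound 3 `COCCNc1nc(C)cc2nn(-c3ccccc3)c(N)c12`: -123%

All three were tested in an assay on isolated protein for inhibition of protein kinase C zeta type (Homo sapiens), read by mobility shift assay, tested at 30 uM; on this read-out lower numbers stand for less inhibition and higher numbers for more inhibition at the one concentration tested (going by the name of the read-out). Compound 1 and compound 2 share one core and differ in a single place: piperidin-1-yl in place of (2-methoxyethyl)amino on an aromatic carbon. This change produced a number 142 percentage points lower from compound 2 to compound 1 (beyond the scatter), a large step on this read-out. Compound 3 carries a different core; how the two cores differ is not broken down here. Within its own core, compound 3 stands closer to compound 1 than to compound 2, as the values above show.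

Compound 4 `Cc1cc2nn(-c3ccccc3)c(N)c2c(N2CCCCC2)n1` has not yet been measured in this assay. It is related to compound 3 by the same change that relates compound 2 to compound 1: piperidin-1-yl in place of (2-methoxyethyl)amino on an aromatic carbon. Because the earlier change gave a number 142 percentage points lower from compound 2 to compound 1 (beyond the scatter), a step in the same direction is expected from compound 3 to compound 4, though a smaller one, since compound 3 already starts at -123% rather than near where compound 2 stands, at -10%. The step from compound 3 to compound 4 is estimated at a number 67 percentage points lower from compound 3 to compound 4 (beyond the scatter). Compound 4 is therefore expected to give -190% in this assay, most likely between -280% and -110%.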

Compound 4, a percentage reported as inhibition, at one concentration (the size of the read-out at that concentration, not a potency): -96%
The estimate for compound 4 lay 94 percentage points below the measured number, outside the stated range (above it).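

In this assay, putting piperidin-1-yl in place of (2-methoxyethyl)amino on the aromatic carbon gave a number 27 percentage points higher from compound 3 to compound 4 (beyond the scatter), a modest step. The change therefore does not carry over from one core to the other in either size or direction: the same change on two cores in this assay, a number 142 percentage points lower (beyond the scatter) from compound 2 to compound 1 and a number 27 percentage points higher (beyond the scatter) from compound 3 to compound 4, 169 percentage points apart, beyond the scatter of two such steps. Among the compounds shown here, with only two pairs, this shows that the outcome of the change depends on the core in this small set, but it does not show why, how the change would behave on a third core, or that the higher number means real inhibition, as compound 4 still reads -96%.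

The compounds shown leave open whether this disagreement between the cores is peculiar to piperidin-1-yl or would also appear with another amine, such as morpholin-4-yl or dimethylamino, or with a longer chain such as (3-methoxypropyl)amino. They also leave open whether any group on this aromatic carbon, on either core, would give a positive reading.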